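Swapping Nitro for Fluoro on the Amide Aryl Ring

The source may hold more compounds than are shown below. What is called first, only, known or untested is meant among the compounds shown, and "the series" means these compounds.

Measured so far:
compound 1 `O=C(NCc1ccc(CNS(=O)(=O)c2ccccc2)cc1)c1ccc([N+](=O)[O-])cc1`: 100 nM
compound 2 `Cc1ccc(S(=O)(=O)NCc2ccc(CNC(=O)c3ccc([N+](=O)[O-])cc3)cc2)cc1`: 10 nM
compound 3 `Cc1ccc(S(=O)(=O)NCc2ccc(CNC(=O)c3cccnc3)cc2)cc1`: > 1000 nM

Of the compounds shown here, three built on the same core have been tested in an assay on MDA-MB-231 cells for binding affinity to C-X-C chemokine receptor type 4 (Homo sapiens), read by immunofluorescence and microscopy, with stated times of 10 min and 30 min; a higher number here means that more compound is needed for the effect, a lower number that less compound is needed. Compound 1 gives 100 nM, the highest of the two real numbers. Compound 2 gives 10 nM, and the step of a 10-fold lower number from compound 1 to compound 2 (1.00 log units; beyond the scatter) is clear. For compound 3 the result is only a limit, > 1000 nM, not a number. The step of an at least 100-fold higher number from compound 2 to compound 3 (2.00 log units; beyond the scatter) therefore marks a large loss when the 4-nitrophenyl group is exchanged for pyridin-3-yl, as the limit of > 1000 nM in this assay, at which 1 of the 3 values shown sits, records.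

Compound 4 `O=C(NCc1ccc(CNS(=O)(=O)c2ccccc2)cc1)c1ccc(F)cc1` is not yet measured. It differs from compound 1 only here: fluoro in place of nitro on an aromatic carbon. The step from compound 1 to compound 2 changes a different part of the molecule and says little about this change. The step from compound 2 to compound 3 replaces the whole 4-nitrophenyl group and costs a great deal, so the nitro end of the molecule appears to matter. Since compound 4 keeps the phenyl ring but loses the nitro, a rise in the number is expected, smaller than that large step. Compound 4 is estimated at 400 nM, within 100 nM to 2000 nM. This expectation corresponds to a 4.0-fold higher number from compound 1 to compound 4 (0.60 log units; beyond the scatter).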

Compound 4, effective concentration (reported as EC, without a stated level of effect): 100 nM
Beside the measured number, compound 4's estimate is 4.0-fold (0.60 log units) above it; the measured number falls inside the stated range.
By their numbers in this assay, from the lowest: compound 2; then compounds 1 and 4 (each within the scatter of the next). At a limit, above all of these: compound 3.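

In this assay, fluoro in place of nitro gives no change at the digits printed from compound 1 to compound 4 (within the scatter), even though a single fluorine atom replaces a group of three heavy atoms and the hydrogen-bond acceptors counted on the nitro group leave with it. The earlier step, an at least 100-fold higher number from compound 2 to compound 3 (2.00 log units; beyond the scatter), exchanged the ring and its substituent together, so it could not separate the two; this new pair keeps the phenyl ring and shows that, on the core of compound 1, the nitro group itself is not needed for a value of this size. Nothing measured here explains why these two groups give the same value.

On these data alone, it remains open whether the same exchange would also leave the value unchanged in the methyl-bearing compound 2, which is the compound with the lowest number. As far as these compounds go, it is also open how the phenyl ring would behave with plain hydrogen, an amine or a carboxylic acid in this same place, and so whether any group is needed there at all.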